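A few compounds are considered here, and "the series" means these few. Any claim that something is new, unique, unknown or untested is made for them only; others in the source may bear on it.

Measured compounds:
- compound 1, `CN(C(=O)NC(=O)c1c(F)cccc1F)c1nc(C(F)(F)F)c(C(=O)N/N=C/c2cccc(C(F)(F)F)c2)s1`: 21.8 ug/mL
- compound 2, `Cc1nc(N(C)C(=O)NC(=O)c2c(F)cccc2F)sc1C(=O)N/N=C/c1cccc(C(F)(F)F)c1`: 28.2 ug/mL
- compound 3, `CN(C(=O)NC(=O)c1c(F)cccc1F)c1nc(C(F)(F)F)c(C(=O)N/N=C/c2cc(C(F)(F)F)cc(C(F)(F)F)c2)s1`: 6.85 ug/mL

In a functional assay on MCF7 cells (Homo sapiens) for inhibition, read by MTT assay, with a stated time of 72 h (a higher number here means a weaker inhibitor, a lower number a stronger inhibitor), compound 1 gives 21.8 ug/mL, the second highest of the three numbers. Its nearest neighbour is compound 2, where a 1.3-fold higher number from compound 1 to compound 2 (0.11 log units; within the scatter), a change that stays within the scatter. The furthest is compound 3, where a 3.2-fold lower number from compound 1 to compound 3 (0.50 log units; beyond the scatter).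

Compound 4, `CN(C(=O)NC(=O)c1c(F)cccc1F)c1nc(C(F)(F)F)c(C(=O)N/N=C/c2ccccc2C(F)(F)F)s1`, has not been measured. It keeps every atom of compound 1 but joins them differently: 2-(trifluoromethyl)phenyl in place of 3-(trifluoromethyl)phenyl on a carbon with a double bond to nitrogen. Neither measured step speaks directly to this change. The step from compound 1 to compound 2 alters the core, not the aryl group on the hydrazone carbon, and the step from compound 1 to compound 3 adds a group rather than moving one. For the measured compounds named here, the only guidance is that the aryl group matters, since the second trifluoromethyl in compound 3 lowered the number beyond the scatter. Moving a single trifluoromethyl gives no such anchor, so the expectation for compound 4 in this assay is a step of a 1.0-fold higher number from compound 1 to compound 4 (0.00 log units; within the scatter), which is no change beyond the scatter. The estimate for compound 4 is 22 ug/mL, with a range from 10 ug/mL to 48 ug/mL.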

Compound 4, half-maximal inhibitory concentration: 20.4 ug/mL
Estimate against measurement, compound 4: 1.1-fold (0.03 log units) above, within the range that was stated.
By their numbers in this assay, from the lowest: compound 3; then compounds 4, 1 and 2 (each within the scatter of the next).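

Exchanging 3-(trifluoromethyl)phenyl for 2-(trifluoromethyl)phenyl on the carbon with a double bond to nitrogen gives a 1.1-fold lower number from compound 1 to compound 4 (0.03 log units; within the scatter) in this assay. The earlier compounds shown here showed only that adding a second trifluoromethyl to this aryl group gave a 3.2-fold lower number from compound 1 to compound 3 (0.50 log units; beyond the scatter), and they said nothing about where a single trifluoromethyl stands on it. The new pair adds that, for these two groups, the placement of a single trifluoromethyl cannot be told apart in this assay, so this exchange does not reproduce the step seen on adding a second trifluoromethyl. Nothing available explains why the two groups read alike.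

The compounds shown leave open whether an amine, a carboxylic acid or a methoxy group in place of the trifluoromethyl on this aryl ring would shift the number beyond the scatter. They also leave open whether the same exchange of 3-(trifluoromethyl)phenyl for 2-(trifluoromethyl)phenyl would read alike on the core of compound 2 , which carries a methyl where compound 1 carries a trifluoromethyl.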